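The source may hold more compounds than are shown below. What is called first, only, known or untested is meant among the compounds shown, and "the series" means these compounds.

In a functional assay on L1210 cells (Mus musculus) for antiproliferative activity (on this read-out higher numbers stand for weaker inhibition and lower numbers for stronger inhibition), compound 1 `Cc1nsc2c1ncn2[C@@H]1O[C@H](CO)[C@@H](O)[C@H]1O` gives 10000 nM. Compound 2 `CSc1nc2c(C)nsc2n1[C@@H]1O[C@H](CO)[C@@H](O)[C@H]1O` reaches only a limit, > 100000 nM, in this assay. Compound 2 thus sits at the limit of > 100000 nM in this assay, at which 1 of the 2 values shown sits. That step is an at least 10-fold higher number from compound 1 to compound 2 (1.00 log units; beyond the scatter). Compound 3 `Cc1nsc2c1nc(SCc1ccccc1)n2[C@@H]1O[C@H](CO)[C@@H](O)[C@H]1O` differs from compound 2 by phenyl in place of hydrogen on a saturated chain carbon bound to a sulfur. Among the measured compounds shown here, no measured step touches this change, since the only step seen concerns a different place. The expected step is a number no higher from compound 2 to compound 3 (the limit leaves the size open), which most likely leaves compound 3 at a limit again. The estimate for compound 3 in this assay is 100000 nM, between 20000 nM and 300000 nM.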

Compound 3, half-maximal inhibitory concentration: > 100000 nM
Compound 3: only a limit was reported; the forecaster's own chance of this, stated with the estimate: 70%; the middle value sits exactly at the limit.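

With benzylsulfanyl in place of hydrogen on the aromatic carbon, this assay shows an at least 10-fold higher number from compound 1 to compound 3 (1.00 log units; beyond the scatter), so a second sulfur-linked group at this position moves the same way as methylsulfanyl. Compound 3 gives only a limit, > 100000 nM. Adding phenyl to the saturated chain carbon bound to a sulfur therefore has no readable effect, since compound 2 and compound 3 both stand at the limit: the limit of > 100000 nM in this assay, at which 2 of the 3 values shown sit.

From the compounds shown here alone, how far compound 2 and compound 3 lie beyond that limit stays open. So does how an amine or a carboxylic acid on this aromatic carbon would read in this assay.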